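The compounds below may be only part of what the source reports. "The series", "measured", "known", "first", "only" and "open" are said of these compounds alone.

Compounds measured in a functional assay on NCI-H1299 cells (Homo sapiens) for antiproliferative activity, read by MTT assay, with a stated time of 72 h; on this read-out higher numbers stand for weaker inhibition and lower numbers for stronger inhibition:
- compound 1 `Cc1ccc(NC2=C(C(=O)c3ccccc3)C(c3ccc(Br)cc3)N(CCCn3ccnc3)C2=O)cc1`: 25800 nM
- compound 2 `O=C(C1=C(Nc2ccc(I)cc2)C(=O)N(CCCn2ccnc2)C1c1ccc(Br)cc1)c1ccccc1`: 19400 nM

Compound 2 gives the lowest of the two numbers in this assay, but its nearest neighbour, compound 1, differs by a 1.3-fold lower number from compound 1 to compound 2 (0.12 log units; within the scatter), so the two sit within the scatter of each other and no order between them can be claimed.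

Compound 3 `O=C(C1=C(Nc2ccc(Cl)cc2)C(=O)N(CCCn2ccnc2)C1c1ccc(Br)cc1)c1ccccc1` has not been measured. It differs from compound 2 by chloro in place of iodo on an aromatic carbon. Going by the values given here, the only measured step that touches the same position, iodo in place of methyl, was a 1.3-fold lower number from compound 1 to compound 2 (0.12 log units; within the scatter), within the scatter. A second change at that same aromatic carbon, to chloro, is therefore expected to give no step beyond the scatter either, so the step from compound 2 to compound 3 is estimated at a 1.1-fold higher number from compound 2 to compound 3 (0.05 log units; within the scatter). Compound 3 is expected to give 22000 nM in this assay, with a range from 10000 nM to 48000 nM.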

Compound 3, half-maximal inhibitory concentration: 25000 nM
The estimate for compound 3 lay 1.1-fold (0.06 log units) below the measured number; the range from low to high includes it.
By their numbers in this assay, from the lowest: compounds 2, 3 and 1 (each within the scatter of the next).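

Exchanging iodo for chloro on this aromatic carbon, para to a large group, gives in this assay a step of a 1.3-fold higher number from compound 2 to compound 3 (0.11 log units; within the scatter) and so adds a third substituent whose number cannot be told apart from the others. Chloro in place of methyl gives a 1.0-fold lower number from compound 1 to compound 3 (0.01 log units; within the scatter) and is equally unresolved, so methyl, iodo and chloro at this carbon now form a set of three with no step among them beyond the scatter, where the earlier compounds offered only a single pair. No measurement bears on why this position tolerates these exchanges.

On these data alone, whether an amine or a carboxylic acid on the same carbon would give a step beyond the scatter remains open. So does whether this position matters at all, since the three compounds share the rest of their structure and all their numbers lie close together.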